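The compounds below may be only part of what the source reports. "The series", "measured", "known", "first", "only" and "open" are said of these compounds alone.

Measured so far:
compound 1 `CC(C)[C@H](C[C@H]1CCNC1=O)c1ccc(-c2ccc3cccc(F)c3c2)[nH]c1=O` — 0.257 h
compound 2 `CCn1ncc2c(F)cc(-c3ccc(C(CC)(CC)c4ncn(C)n4)c(=O)[nH]3)cc21` — > 3 h
compound 3 `CC(C)C(c1ccc(-c2ccc3cccc(F)c3c2)[nH]c1=O)N1CCNC1=O` — 1.03 h

Of the compounds shown here, three have been tested in an ADME assay on microsomes from liver (Homo sapiens) for metabolic stability; a lower number here means that the compound disappears faster, a higher number that the compound lasts longer. Compound 1 `CC(C)[C@H](C[C@H]1CCNC1=O)c1ccc(-c2ccc3cccc(F)c3c2)[nH]c1=O` gives 0.257 h. Compound 2 `CCn1ncc2c(F)cc(-c3ccc(C(CC)(CC)c4ncn(C)n4)c(=O)[nH]3)cc21` reaches only a limit of this assay, > 3 h, so it yields no number. Compound 3 `CC(C)C(c1ccc(-c2ccc3cccc(F)c3c2)[nH]c1=O)N1CCNC1=O` gives 1.03 h, the higher of the two numbers; its nearest neighbour is compound 1, which sits at a lower value, a gap beyond the scatter. That one value of the three sits at a limit is noted here: the limit of > 3 h in this assay, at which 1 of the 3 values shown sits.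

The piece now follows the step from compound 3 to compound 4 `CC(C)C(Nc1nnc[nH]1)c1ccc(-c2ccc3cccc(F)c3c2)[nH]c1=O`, which has not yet been measured in this assay. The structural change is (4H-1,2,4-triazol-3-yl)amino in place of 2-oxoimidazolidin-1-yl on a saturated chain carbon bound to an aromatic carbon and a saturated chain carbon. For the measured compounds named here, no step between measured compounds that differ in one place is available, so no measured change of the same kind can be pointed to. The change swaps one group for another of equal atom count at the same place, and without a comparable step the expected size of the effect is small: the step from compound 3 to compound 4 is expected to stay within the scatter, a 1.0-fold lower number from compound 3 to compound 4 (0.01 log units; within the scatter). For compound 4 the estimated value in this assay is 1 h, with a range from 0.4 h to 2.5 h.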

Compound 4, half-life: > 3 h
Compound 4: a limit, no number (the forecaster's own chance of this, stated with the estimate: 10%); middle value at least 3.0-fold (0.47 log units) from the limit.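

In this assay, for the compounds shown here, the exchange of 2-oxoimidazolidin-1-yl for (4H-1,2,4-triazol-3-yl)amino on a saturated chain carbon bound to an aromatic carbon and a saturated chain carbon gives an at least 2.9-fold higher number from compound 3 to compound 4 (0.46 log units; beyond the scatter) and this is the first change in one place that can be read here. It shows that the group held on this carbon matters for how long the compound lasts, even though the rest of the molecule stays the same and the leaving and entering groups have the same number of heavy atoms. Going by these compounds, compound 4 gives a limit, not a number, in this assay so the full size of the step stays unknown: the limit of > 3 h in this assay, at which 2 of the 4 values shown sit.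

The exchange alters the ring type, the hetero atoms and the hydrogen-bond donors and acceptors all at once, so this single pair cannot say which of these goes with the longer half-life. On these data alone, how a plain amine or a pyrazol-3-ylamino group would behave on this carbon stays open, as does whether the same exchange would have a like effect on another core.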